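Dimethoxyphenyl in Place of Phenylethenyl: an Expected Gain

The source may hold more compounds than are shown below. What is called first, only, known or untested is meant among the compounds shown, and "the series" means these compounds.

Compound 1 `Cc1cc(O)c(C2=NN(c3ccc(S(N)(=O)=O)cc3)C(c3ccccc3O)C2)cc1Cl`: 2210 nM
Compound 2 `Cc1cc(O)c(C2=NN(c3ccc(S(N)(=O)=O)cc3)C(c3ccccc3Cl)C2)cc1Cl`: 3030 nM
Compound 3 `Cc1cc(O)c(C2=NN(c3ccc(S(N)(=O)=O)cc3)C(/C=C/c3ccccc3)C2)cc1Cl`: 5210 nM

Among these three, compound 3 stands highest in a functional assay on NCI-H226 cells (Homo sapiens) for antiproliferative activity, with a stated time of 48 h; on this read-out lower numbers stand for stronger inhibition of growth and higher numbers for weaker inhibition of growth. The step of a 2.4-fold higher number from compound 1 to compound 3 (0.37 log units; beyond the scatter) lies beyond the scatter, while the step of a 1.7-fold higher number from compound 2 to compound 3 (0.24 log units; within the scatter) lies within it, so compound 3 is separated clearly only from compound 1.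

Compound 4 `COc1ccc(C2CC(c3cc(Cl)c(C)cc3O)=NN2c2ccc(S(N)(=O)=O)cc2)cc1OC` has not yet been measured. It differs from compound 3 in one place: 3,4-dimethoxyphenyl in place of 2-phenylethenyl on a saturated ring carbon. The two measured steps that bear on this change are the ones that exchange an aromatic ring on that same saturated ring carbon for the 2-phenylethenyl group, a 2.4-fold higher number from compound 1 to compound 3 (0.37 log units; beyond the scatter) and a 1.7-fold higher number from compound 2 to compound 3 (0.24 log units; within the scatter). Read in reverse, both say that restoring an aromatic ring at that carbon lowers the number, modestly in one case and within the scatter in the other. Nothing measured speaks to the 3,4-dimethoxyphenyl group itself, so a new aromatic substitution pattern could land anywhere near where compounds 1 and 2 sit. Compound 4 is therefore expected to give 3000 nM, with a range from 1500 nM to 6500 nM. That expectation amounts to a 1.7-fold lower number from compound 3 to compound 4 (0.24 log units; within the scatter), a step toward stronger inhibition of roughly the size seen between the aromatic rings and the 2-phenylethenyl group.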

Compound 4, concentration for 50% growth inhibition: 5620 nM
The estimate for compound 4 lay 1.9-fold (0.27 log units) below the measured number, and the stated range covers the measured number.
By their numbers in this assay, from the lowest: compounds 1, 2, 3 and 4 (each within the scatter of the next, the first and the last beyond it).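

In this assay, putting 3,4-dimethoxyphenyl on the saturated ring carbon in place of 2-phenylethenyl gives a 1.1-fold higher number from compound 3 to compound 4 (0.03 log units; within the scatter), so an aromatic ring at this carbon does not by itself set a compound apart from compound 3, and compound 4 goes against the reading that compounds 1 and 2 had suggested. Among the aromatic rings, the step of a 1.9-fold higher number from compound 2 to compound 4 (0.27 log units; within the scatter) stays within the scatter while the step of a 2.5-fold higher number from compound 1 to compound 4 (0.41 log units; beyond the scatter) lies beyond it, so compound 1 is separated clearly from compounds 3 and 4, whereas compound 2 is separated clearly from none of the three. No measurement is at hand that accounts for this outcome.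

As far as these compounds go, it remains open whether a 2-methoxyphenyl, 2-aminophenyl or 4-hydroxyphenyl group at this carbon would stand with compound 1 or with compound 4, which would show how far the separation belongs to the 2-hydroxyphenyl group in particular. Also open, from the compounds shown here alone, is what this carbon would tolerate with no ring on it at all, such as a short alkyl chain or a carboxylic acid.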